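Swapping a benzyl substituent: trifluoromethyl to bromo

A few compounds are considered here, and "the series" means these few. Any claim that something is new, unique, unknown or untested is made for them only; others in the source may bear on it.

Of the compounds shown here, three sharing one core have been measured in a toxicity assay on MCF-10A cells (Homo sapiens) for inhibition, read by MTT assay, with a stated time of 72 h; a higher number here means a weaker inhibitor of growth, a lower number a stronger inhibitor of growth. Compound 1 `O=S(=O)(NCCCNCc1ccccc1Cl)c1cc(C(F)(F)F)cc(C(F)(F)F)c1` gives 11000 nM, compound 2 `O=S(=O)(NCCCNCc1ccc(Cl)c(C(F)(F)F)c1)c1cc(C(F)(F)F)cc(C(F)(F)F)c1` gives 7900 nM, and compound 3 `O=S(=O)(NCCCNCc1ccc(C(F)(F)F)cc1)c1cc(C(F)(F)F)cc(C(F)(F)F)c1` gives 3300 nM. Compound 3 thus has the lowest number of the three: the step of a 2.4-fold lower number from compound 2 to compound 3 (0.38 log units; beyond the scatter) and the step of a 3.3-fold lower number from compound 1 to compound 3 (0.52 log units; beyond the scatter) both lie beyond the scatter, while a 1.4-fold lower number from compound 1 to compound 2 (0.14 log units; within the scatter) does not.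

Compound 4 `O=S(=O)(NCCCNCc1ccc(Br)cc1)c1cc(C(F)(F)F)cc(C(F)(F)F)c1` differs from compound 3 in one spot: bromo in place of trifluoromethyl on an aromatic carbon. Among the measured compounds shown here, no measured step changes exactly this group on this carbon. The nearest guides are the steps that altered the substituents on the same benzyl ring: a 2.4-fold lower number from compound 2 to compound 3 (0.38 log units; beyond the scatter) and a 3.3-fold lower number from compound 1 to compound 3 (0.52 log units; beyond the scatter), each modest, and the former shows that trimming a 4-chloro-3-(trifluoromethyl)phenyl to a 4-(trifluoromethyl)phenyl moved the number only modestly. Replacing trifluoromethyl with bromo on the same ring carbon is a smaller rearrangement than either of those, so the expected step of a 1.4-fold higher number from compound 3 to compound 4 (0.13 log units; within the scatter) is small and may fall within the scatter, leaning toward a somewhat higher number since compound 3 already sits lowest. Compound 4 is therefore estimated at 4500 nM, with a likely range from 1800 nM to 12000 nM.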

Compound 4, concentration for 50% growth inhibition: 3100 nM
The estimate for compound 4 lay 1.5-fold (0.16 log units) above the measured number; the measured number falls inside the stated range.
By their numbers in this assay, from the lowest: compounds 4 and 3 (each within the scatter of the next); then compounds 2 and 1 (each within the scatter of the next).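

In this assay the four heavy atoms of trifluoromethyl give way to the single bromine atom on this aromatic carbon, para to a large group, and the result is a 1.1-fold lower number from compound 3 to compound 4 (0.03 log units; within the scatter) and so no readable change, which means that at this carbon the two groups cannot be told apart in this read-out. The distance from the other two compounds also persists with bromo in place: the data show a 2.5-fold lower number from compound 2 to compound 4 (0.41 log units; beyond the scatter) and a 3.5-fold lower number from compound 1 to compound 4 (0.55 log units; beyond the scatter) and both steps are modest, so the 4-bromophenyl and 4-(trifluoromethyl)phenyl compounds sit together, apart from the 4-chloro-3-(trifluoromethyl)phenyl and 2-chlorophenyl compounds. No supporting measurement is available to explain why the two groups read alike.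

Whether this match extends to a methoxy, a nitrile or a plain hydrogen on the same carbon remains open among the compounds shown. Also open, from the compounds shown here alone, is whether the same exchange would read alike with a longer chain between the two nitrogens of the shared core.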